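A few compounds are considered here, and "the series" means these few. Any claim that something is new, unique, unknown or untested is made for them only; others in the source may bear on it.

The three measured compounds share one core and differ only in the aryl group attached to it. Compound 1 `Cc1nc2c3ccccc3ccc2c2nc3c(ccc4ccccc43)c(-c3cccc4ccccc34)c12` carries a naphthalen-1-yl group, and in a functional assay, read by spectrophotometry, with a stated time of 30 min (on this read-out higher numbers stand for weaker inhibition and lower numbers for stronger inhibition), compound 1 gives 111 ug/mL. Compound 2 `Cc1nc2c3ccccc3ccc2c2nc3c(ccc4ccccc43)c(-c3ccccc3N)c12` carries a 2-aminophenyl group, and in this assay compound 2 gives 95.4 ug/mL. Compound 3 `Cc1nc2c3ccccc3ccc2c2nc3c(ccc4ccccc43)c(-c3ccccc3Cl)c12` carries a 2-chlorophenyl group, and in this assay compound 3 gives 118 ug/mL. On the numbers shown, compound 3 lies nearest to compound 1 and a little further from compound 2, the gaps being a 1.1-fold higher number from compound 1 to compound 3 (0.03 log units; within the scatter) and a 1.2-fold higher number from compound 2 to compound 3 (0.09 log units; within the scatter), both within the scatter, so the three compounds cannot be told apart.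

Compound 4 `Cc1nc2c3ccccc3ccc2c2nc3c(ccc4ccccc43)c(-c3ccccc3)c12` has not yet been measured in this assay. It differs from compound 3 by hydrogen in place of chloro on an aromatic carbon. Two of the measured steps bear on this change: the replacement of naphthalen-1-yl by 2-chlorophenyl, a 1.1-fold higher number from compound 1 to compound 3 (0.03 log units; within the scatter), and the replacement of amino by chloro, a 1.2-fold higher number from compound 2 to compound 3 (0.09 log units; within the scatter). Both left the number essentially where it was, and nothing in the data singles out the chloro group as mattering. The step of a 1.1-fold lower number from compound 3 to compound 4 (0.03 log units; within the scatter) is therefore expected to be of no size beyond the scatter. The estimate for compound 4 in this assay is 110 ug/mL, within a range of 70 ug/mL to 170 ug/mL.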

Compound 4, half-maximal inhibitory concentration: 164 ug/mL
Estimate against measurement, compound 4: 1.5-fold (0.17 log units) below, and the stated range covers the measured number.
By their numbers in this assay, from the lowest: compounds 2, 1, 3 and 4 (each within the scatter of the next).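

With hydrogen in place of chloro in this assay, the result is a 1.4-fold higher number from compound 3 to compound 4 (0.14 log units; within the scatter) and so the chloro group is shown to be dispensable at this place, on an aromatic carbon of the six-membered ring, without the number leaving the scatter. Going by these compounds alone, the same holds for the amino group, where the comparison gives a 1.7-fold higher number from compound 2 to compound 4 (0.24 log units; within the scatter) and for the larger aryl group, where phenyl in place of naphthalen-1-yl gives a 1.5-fold higher number from compound 1 to compound 4 (0.17 log units; within the scatter) and so neither the second ring of the naphthalen-1-yl group nor either substituent on the phenyl ring is needed to keep the number in this range, a point the earlier compounds, all carrying a substituted or larger aryl group, could not show. No measurement offered here accounts for why these changes leave the number within the scatter.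

Whether any group at this place can move the number beyond the scatter stays open, since a carboxylic acid, a methoxy group or a longer alkyl chain in place of the chloro does not appear among these compounds. Also open, as far as these compounds go, is how much the number depends on the shared core, which is the same in all four compounds.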